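The compounds below may be only part of what the source reports. "The series", "measured", "known", "first", "only" and "open" are said of these compounds alone.

Measured compounds:
compound 1, `Cc1nc2c(COc3ccccc3)cccn2c1C`, 48%;
compound 2, `Cc1nc2c(C[S+]([O-])c3ccccc3)cccn2c1C`, 42%;
compound 3, `CCSCc1c(C)nc2c(OCc3ccccc3)cccn12`, 36%.

All three were run in a functional assay on the whole organism with Rattus norvegicus as the target, with a stated time of 4 h, at a dose of 40 mg/kg by the intraperitoneal route; on this read-out higher numbers stand for more inhibition at the one dose given (going by the name of the read-out) and lower numbers for less inhibition. Compound 3 holds the smallest of the three numbers. Its gap to compound 2 lies within the scatter of repeated measurements, so no order between compound 3 and compound 2 can be read from these two values. Its gap to compound 1 lies beyond the scatter, so compound 1 gives more inhibition than compound 3 in this assay.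

Compound 4, `Cc1nc2c(OCc3ccccc3)cccn2c1COC(=O)N(C)C`, has not been measured. It differs from compound 3 in one place: (dimethylcarbamoyl)oxy in place of ethylsulfanyl on a saturated chain carbon bound to an aromatic carbon. Going by the values given here, no measured pair shows this change, so no step size is known for it. With nothing to go on beyond the shared core and the three values above, the expected step in this assay is one that does not clear the scatter in either direction; the expected step is a number 4 percentage points higher from compound 3 to compound 4 (within the scatter). Compound 4 is estimated at 40%, with a range from 20% to 60%.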

Compound 4, a percentage reported as inhibition, in the whole organism at one dose (the size of the read-out at that dose, not a potency): 75%
Beside the measured number, compound 4's estimate is 35 percentage points below it, and the stated range ends below it.
By their numbers in this assay, from the lowest: compounds 3, 2 and 1 (each within the scatter of the next, the first and the last beyond it); then compound 4.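

In this assay, (dimethylcarbamoyl)oxy in place of ethylsulfanyl on a saturated chain carbon bound to an aromatic carbon gives a number 39 percentage points higher from compound 3 to compound 4 (beyond the scatter), so the read-out responds strongly to what this position carries. The earlier compounds shown here could not show this, as they differ from each other in more than one place and no step could be read among them. Nothing on hand explains the size of this step.

On these data alone, whether the rise needs the whole (dimethylcarbamoyl)oxy group stays open: a hydroxyl, an acetoxy group or a dimethylamino group on the same carbon would help separate its parts. Also open, as far as these compounds go, is whether a step of this size would carry over to the arrangement of groups in compound 1, or would hold at other doses.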